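Swapping One Aromatic Group in a Growth Inhibition Series

The compounds below may be only part of what the source reports. "The series", "measured", "known", "first", "only" and "open" are said of these compounds alone.

In a functional assay on THP-1 cells (Homo sapiens) for inhibition, with a stated time of 48 h, tested at 50 uM (a higher number here means more inhibition of growth at the concentration tested, a lower number less inhibition of growth), compound 3 `COc1ccccc1/C=C/[C@@](C)(/C=C/c1ccc(O)cc1)CCC=C(C)C` gives 62%. Going by the values given here, compound 1 `C=C[C@@](C)(/C=C/c1ccc(OC(=O)CCCCCCCCCCCCCCC)cc1)CCC=C(C)C` gives 62%, level with compound 3 within the usual scatter, and together they hold the lowest reading of the three measured so far. Compound 2 `CC1C(C(C)(C)O)CCC1(C)/C=C/c1ccc(O)cc1` gives 93%, which lies beyond the scatter from compound 3.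

The next compound, compound 4 `CC(C)=CCC[C@@](C)(/C=C/c1ccc(N)cc1)/C=C/c1ccc(O)cc1`, has 4-aminophenyl in place of 2-methoxyphenyl on a double-bonded chain carbon bound to a double-bonded chain carbon. Among the compounds with values here, no measured pair shows this exchange, so the data offer little guidance. The expected a number 6 percentage points higher from compound 3 to compound 4 (within the scatter) in this assay is small and upward, probably within the scatter. For compound 4, the estimated value is 68%, with an expected range of 48% to 90%.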

Compound 4, percent growth inhibition at one concentration: 51%
Compound 4: the middle estimate sits 17 percentage points above what was measured, within the range that was stated.
By their numbers in this assay, from the lowest: compound 4; then compounds 1 and 3 (each within the scatter of the next); then compound 2.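

This first readable step in the series shows that the aromatic group on a double-bonded chain carbon bound to a double-bonded chain carbon can shift the reading in this assay. Placing 4-aminophenyl there in place of 2-methoxyphenyl gives a number 11 percentage points lower from compound 3 to compound 4 (beyond the scatter) and is a modest change. Nothing measured here explains this drop.

The exchange alters both the substituent and where it sits on the ring, and the compounds shown do not separate the two. On these data alone, how a 4-methoxyphenyl or a 2-aminophenyl group would read here remains open.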